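Trimming the amine on a biaryl benzylamine

A few compounds are considered here, and "the series" means these few. Any claim that something is new, unique, unknown or untested is made for them only; others in the source may bear on it.

Three close relatives of one biaryl scaffold have been measured in an assay on HEK293 cells for displacement of a labelled ligand from 5-hydroxytryptamine receptor 7 (Homo sapiens), read by scintillation counting, with a stated time of 1.5 h, in the absence of a further agent; a higher number here means a weaker inhibitor, a lower number a stronger inhibitor. Among the compounds with values here, compound 1 `COc1ccccc1-c1cccc(CN(C)C)c1` gives 126 nM, and compound 2 `COc1ccccc1-c1cc(CN(C)C)ccc1Cl` gives 18 nM; the only change between them is a 7.0-fold lower number from compound 1 to compound 2 (0.85 log units; beyond the scatter). Compound 3 `COc1ccccc1-c1cc(CN2CCC(C)CC2)ccc1OC` gives 3060 nM, the highest of the three numbers, standing well apart from compound 1 and further still from compound 2.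

Compound 4 `COc1ccccc1-c1cc(CN(C)C)ccc1OC` is the next step. The change from compound 3 is dimethylamino in place of 4-methylpiperidin-1-yl on a saturated chain carbon bound to an aromatic carbon, so compound 4 keeps the methoxy-bearing ring of compound 3 but carries the same amine as compounds 1 and 2. Within the data shown here, no measured pair isolates this amine swap, and the measured step from compound 1 to compound 2 concerns a different position, so it gives no direct guide. Since both compounds that carry the dimethylamino group sit far lower than compound 3 in this assay, compound 4 is expected to move downward, by roughly a 7.7-fold lower number from compound 3 to compound 4 (0.88 log units; beyond the scatter), though with wide uncertainty. For compound 4 the estimate in this assay is 400 nM, within 80 nM to 2000 nM.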

Compound 4, inhibition constant: 1020 nM
The estimate for compound 4 lay 2.6-fold (0.41 log units) below the measured number; the range from low to high includes it.
By their numbers in this assay, from the lowest: compound 2; then compound 1; then compound 4; then compound 3.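

Swapping the amine alone moves the number only modestly (a 3.0-fold lower number from compound 3 to compound 4 (0.48 log units; beyond the scatter)), so with methoxy on the aromatic carbon, dimethylamino does not bring the compound close to compound 1 or compound 2. The aromatic carbon that holds methoxy in compound 4 proves much more sensitive: methoxy in place of chloro gives a large step (a 57-fold higher number from compound 2 to compound 4 (1.75 log units; beyond the scatter)), and methoxy in place of hydrogen gives a smaller one (an 8.1-fold higher number from compound 1 to compound 4 (0.91 log units; beyond the scatter)). With dimethylamino held constant, the order at this carbon runs from chloro through hydrogen to methoxy, each change beyond the usual scatter.

Still open, going by these compounds, is whether fluoro or methyl on that carbon would fall nearer chloro or methoxy, and whether 4-methylpiperidin-1-yl would cost the same alongside chloro. No supporting data explain why these groups rank as they do.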